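From 2,4-Difluorophenyl to 4-Methoxyphenyl at the Assay Limit

This account rests on a few compounds, and the source may have more. Where it says the series, first, only, none or still open, it means among the compounds named here.

Of the compounds shown here, three on a shared core have been tested in an ADME assay on Vero cells (Chlorocebus sabaeus) for cytotoxicity; a lower number here means that less compound is tolerated, a higher number that more compound is tolerated. Compound 1 `CC(=O)c1c(N2CCCCC2)[nH]c2c(F)cc(F)cc2c1=O` gives > 25000 nM, which is a limit and not a number. Compound 2 `CC(=O)c1c(OCc2ccc(Cl)c(Cl)c2)[nH]c2c(F)cc(F)cc2c1=O` gives > 25000 nM, again a limit. Compound 3 `CC(=O)c1c(NCc2ccc(F)cc2F)[nH]c2c(F)cc(F)cc2c1=O` gives > 25000 nM, also a limit. The whole set therefore rests on (the limit of > 25000 nM in this assay, at which 3 of the 3 values shown sit).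

Compound 4 `COc1ccc(CNc2[nH]c3c(F)cc(F)cc3c(=O)c2C(C)=O)cc1` carries 4-methoxyphenyl in place of 2,4-difluorophenyl on a saturated chain carbon bound to a nitrogen on an aromatic ring. Within the data shown here, no measured step is available as a guide. The expected step, a step that the limit leaves unreadable from compound 3 to compound 4, is none beyond the scatter. That expectation rests on compound 3, whose limit is > 25000 nM. The estimate for compound 4 is 30000 nM, with an expected range of 15000 nM to 60000 nM.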

Compound 4, half-maximal cytotoxic concentration: > 25000 nM
Compound 4 was reported as a limit; the forecaster's own chance of this, stated with the estimate: 85%; the middle value is on the limit's open side.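

No step can be read from compound 3 to compound 4, as both stand at the limit in this assay: the limit of > 25000 nM in this assay, at which 4 of the 4 values shown sit.

The compounds shown leave open at what concentration any of them becomes cytotoxic, and whether 4-methoxyphenyl in place of 2,4-difluorophenyl alters it.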